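This account rests on a few compounds, and the source may have more. Where it says the series, first, only, none or still open, it means among the compounds named here.

In an ADME assay on CCRF-CEM cells (Homo sapiens) for antiproliferative activity, with a stated time of 48 h (on this read-out higher numbers stand for weaker inhibition and lower numbers for stronger inhibition), compound 1 (`Nc1ccc(/C=C/C(=O)c2ccc(Br)cc2)cc1`) gives 14000 nM and compound 2 (`Nc1ccc(/C=C/C(=O)c2ccc(I)cc2)cc1`) gives 16000 nM while compound 3 (`COc1ccc(C(=O)/C=C/c2ccc(N)cc2)cc1`) gives 37000 nM as the highest number of the three. Compound 4 (`CCOc1ccc(C(=O)/C=C/c2ccc(N)cc2)cc1`) turns methoxy into ethoxy with methyl in place of hydrogen on a saturated chain carbon bound to an oxygen on an aromatic ring as the change. Only exchanges of the group on the aromatic carbon have been measured: a 2.6-fold higher number from compound 1 to compound 3 (0.42 log units; beyond the scatter) for methoxy in place of bromo and a 2.3-fold higher number from compound 2 to compound 3 (0.36 log units; beyond the scatter) for methoxy in place of iodo are modest while a 1.1-fold higher number from compound 1 to compound 2 (0.06 log units; within the scatter) stays within the scatter. Among the measured compounds shown here, no measured step lengthens the methoxy chain, and the change here is smaller than those exchanges. The estimated step is a 1.2-fold lower number from compound 3 to compound 4 (0.09 log units; within the scatter) and none beyond the scatter is expected in this assay here. Compound 4 is estimated at 30000 nM within an expected range of 15000 nM to 60000 nM for this measurement.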

Compound 4, half-maximal inhibitory concentration: 15000 nM
Estimate against measurement, compound 4: 2.0-fold (0.30 log units) above; low and high end bracket the measured number.
By their numbers in this assay, from the lowest: compounds 1, 4 and 2 (each within the scatter of the next); then compound 3.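

In this assay, the number is sensitive to the chain itself: methyl in place of hydrogen, turning methoxy into ethoxy, gives a 2.5-fold lower number from compound 3 to compound 4 (0.39 log units; beyond the scatter). Ethoxy also cannot be told apart from the halogens, with a 1.1-fold lower number from compound 2 to compound 4 (0.03 log units; within the scatter) for iodo replaced by ethoxy and a 1.1-fold higher number from compound 1 to compound 4 (0.03 log units; within the scatter) for bromo replaced by ethoxy, whereas methoxy stood apart from both. No measured evidence bears on the reason for this result.

Open, as far as these compounds go, is whether a longer chain such as propoxy, or a branched isopropoxy, holds this level or departs from it. A hydroxy group or an amine in place of ethoxy also remains to be placed against these compounds.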